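A Quinolin-5-yl Group Replaces 4-(Trifluoromethyl)phenyl in Compound 2

The source may hold more compounds than are shown below. What is called first, only, known or untested is meant among the compounds shown, and "the series" means these compounds.

In a functional assay on MDA-MB-231 cells (Homo sapiens) for antiproliferative activity, read by MTT assay, with a stated time of 48 h (a higher number here means a weaker inhibitor, a lower number a stronger inhibitor), compound 2 (`C=CS(=O)(=O)N1CCN(c2ncnc3sc(-c4ccc(C(F)(F)F)cc4)cc23)CC1`) gives 6410 nM and so the lowest number of the three measured. Compound 3 (`C=CS(=O)(=O)N1CCN(c2ncnc3sc(-c4ccc(OC)cc4)cc23)CC1`) gives 29900 nM and compound 1 (`C=CS(=O)(=O)N1CCN(c2ccn3ncc(-c4ccccc4)c3n2)CC1`) gives 38300 nM in the same test.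

Compound 4 (`C=CS(=O)(=O)N1CCN(c2ncnc3sc(-c4cccc5ncccc45)cc23)CC1`) has not yet been measured. It carries quinolin-5-yl in place of 4-(trifluoromethyl)phenyl on an aromatic carbon next to the ring sulfur (quinolin-5-yl in place of 4-(trifluoromethyl)phenyl on an aromatic carbon) and keeps the rest of compound 2 unchanged.

Among the compounds with values here, only one measured step bears on this change. Methoxy in place of trifluoromethyl on the same aryl group gave a 4.7-fold higher number from compound 2 to compound 3 (0.67 log units; beyond the scatter) as a modest rise. Compound 4 also loses the trifluoromethyl group, but its new group is a different one, so only a rise of similar direction and smaller or comparable size can be expected from that single step. The estimated step is a 2.2-fold higher number from compound 2 to compound 4 (0.34 log units; beyond the scatter) in this assay as a modest rise. For compound 4 the estimated value is 14000 nM within an expected range from 5000 nM to 35000 nM in that test.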

Compound 4, half-maximal inhibitory concentration: 21000 nM
Estimate against measurement, compound 4: 1.5-fold (0.18 log units) below; measured number inside the range.
By their numbers in this assay, from the lowest: compound 2; then compounds 4, 3 and 1 (each within the scatter of the next).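

At the aromatic carbon next to the ring sulfur, a second replacement of 4-(trifluoromethyl)phenyl also raises the number in this assay with a 3.3-fold higher number from compound 2 to compound 4 (0.52 log units; beyond the scatter) and thus a group quite unlike methoxyphenyl moves the same way, leaving compound 2 with the lowest number of the three compounds that share its core. The two replacements are not told apart, since a 1.4-fold lower number from compound 3 to compound 4 (0.15 log units; within the scatter) and a fused quinolin-5-yl with its nitrogen-containing ring therefore stands level with 4-methoxyphenyl at this place. The data available give no explanation for either step.

The compounds shown leave open whether a plain phenyl, or a phenyl carrying chlorine, an amine or a carboxylic acid, would stand with compound 2 or with compound 3 and compound 4. They also leave open whether quinolin-5-yl would behave the same way on the core of compound 1.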